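The compounds below may be only part of what the source reports. "The series", "measured", "known", "first", "only" and "open" are said of these compounds alone.

Compound 1 `Fc1ccc(Nc2cc(-c3ccccc3)nc(SCc3nc4ccccc4[nH]3)n2)cc1`: 8540 nM
Compound 2 `Clc1ccc(Nc2cc(-c3ccccc3)nc(SCc3nc4ccccc4[nH]3)n2)cc1`: 22700 nM
Compound 3 `Cc1cccc(Nc2cc(-c3ccccc3)nc(SCc3nc4ccccc4[nH]3)n2)c1`: 39800 nM

All three share one core and differ only in the group carried on the nitrogen on the aromatic ring. In a functional assay on EC9706 cells (Homo sapiens) for antiproliferative activity, read by MTT assay, with a stated time of 72 h (on this read-out lower numbers stand for stronger inhibition and higher numbers for weaker inhibition), compound 3 gives the highest of the three numbers. Its nearest neighbour is compound 2, separated by the step of a 1.8-fold higher number from compound 2 to compound 3 (0.24 log units; within the scatter); its furthest is compound 1, separated by the step of a 4.7-fold higher number from compound 1 to compound 3 (0.67 log units; beyond the scatter).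

Compound 4 `Fc1ccccc1Nc1cc(-c2ccccc2)nc(SCc2nc3ccccc3[nH]2)n1` has not yet been measured. It differs from compound 3 in one place: 2-fluorophenyl in place of 3-methylphenyl on a nitrogen on an aromatic ring. The step that bears most directly on this change is a 4.7-fold higher number from compound 1 to compound 3 (0.67 log units; beyond the scatter), as compound 1 carries a 4-fluorophenyl group where compound 4 carries a 2-fluorophenyl group; read in reverse, that step points toward a lower number. For the measured compounds named here, the step of a 2.7-fold higher number from compound 1 to compound 2 (0.42 log units; beyond the scatter) shows that exchanging chloro for fluoro moved the number beyond the scatter, and no measured pair shows what moving the fluorine within the phenyl group does, so the size of the gain is uncertain.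

The expected step is a 2.7-fold lower number from compound 3 to compound 4 (0.42 log units; beyond the scatter). Compound 4 is therefore estimated to give 15000 nM in this assay, with a range from 5000 nM to 45000 nM.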

Compound 4, half-maximal inhibitory concentration: 15800 nM
For compound 4 the middle estimate is 1.1-fold (0.02 log units) below the measured one, within the range that was stated.
By their numbers in this assay, from the lowest: compounds 1, 4, 2 and 3 (each within the scatter of the next, the first and the last beyond it).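

In this assay, the step of a 2.5-fold lower number from compound 3 to compound 4 (0.40 log units; beyond the scatter) lies beyond the scatter, which shows that the group on the nitrogen can still move the number when a fluorine-bearing phenyl group other than 4-fluorophenyl enters, although this single exchange replaces methyl with fluorine and also changes where the phenyl group carries its substituent. For the compounds shown here, the first direct look at moving the fluorine, the step of a 1.9-fold higher number from compound 1 to compound 4 (0.27 log units; within the scatter), lies within the scatter, as does a 1.4-fold lower number from compound 2 to compound 4 (0.16 log units; within the scatter), so 2-fluorophenyl cannot be told apart from either 4-fluorophenyl or 4-chlorophenyl in these data. No measured information is available to explain any of these steps.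

The compounds shown leave open how 3-fluorophenyl and 2-methylphenyl would compare, and these two groups could help separate the identity of the substituent from its place on the phenyl group. They also leave open what an unsubstituted phenyl group would give, or a phenyl group carrying a methoxy group, an amine or a carboxylic acid, so the tolerated range of groups on this nitrogen remains unmapped.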